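The compounds below may be only part of what the source reports. "The series", "measured", "known", "first", "only" and "open" are said of these compounds alone.

Working notes on the series, measured in an ADME assay on Hepa-1c1c7 cells (Mus musculus) for cytotoxicity; on this read-out higher numbers stand for weaker inhibition and lower numbers for stronger inhibition:

- compound 1 `CCCCCCCCCC(O)C#CC#C[C@@H](O)[C@H](C)O`: 39800 nM
- compound 2 `CCCCCC(O)C#CC#C[C@@H](O)[C@H](C)O`: > 500000 nM (a limit, not a number)
- compound 3 `CCC/C=C/C(O)C#CC#C[C@@H](O)[C@H](C)O`: 422000 nM

Compound 2 is known only as a limit, > 500000 nM. It therefore gives a floor rather than a fixed starting point for any step away from it.

Next in line is compound 4 `C[C@H](O)[C@H](O)C#CC#CC(O)Cc1ccccc1`, not yet measured. The change is phenyl in place of butyl on a saturated chain carbon, two bonds along the chain from an oxygen on a saturated carbon and a triple-bonded carbon.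

Among the compounds with values here, two measured steps bear on this, and neither introduces a ring. The large one is an at least 12-fold higher number from compound 1 to compound 2 (1.09 log units; beyond the scatter), with hydrogen in place of butyl at a different place on the chain. The closer case is an at least 1.1-fold lower number from compound 2 to compound 3 (0.07 log units; that floor lies within the scatter), with pent-1-en-1-yl in place of pentyl on the carbon bound to the oxygen, and its floor lies within the scatter.

Going by compound 3 (422000 nM), a modest move toward lower numbers is expected, or none beyond the scatter. A reading at the limit remains possible. The expected change is an at least 2.0-fold lower number from compound 2 to compound 4 (0.30 log units; that floor lies within the scatter). The estimate for compound 4 is 250000 nM, with an expected range of 80000 nM to 500000 nM.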

Compound 4, half-maximal inhibitory concentration: > 500000 nM
Compound 4: only a limit was reported; the forecaster's own chance of this, stated with the estimate: 30%; at least 2.0-fold (0.30 log units) between middle value and limit.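

No step can be read from compound 2 to compound 4, because both values are limits and not numbers: the limit of > 500000 nM in this assay, at which 2 of the 4 values shown sit.

The compounds shown leave open whether phenyl in place of butyl on this saturated chain carbon changes the read-out at all, and in which direction.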